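The compounds below may be only part of what the source reports. "The series", "measured", "known", "first", "only" and "open" are said of these compounds alone.

Measured compounds:
compound 1, `COc1cc(-n2cnc3ccc(-c4cc(F)ccc4F)cc32)cc(OC)c1OC`, 7940 nM
compound 2, `COc1ccccc1-c1ccc2ncn(-c3cc(OC)c(OC)c(OC)c3)c2c1`, 4320 nM

Both values come from a functional assay on A549 cells (Homo sapiens) for antiproliferative activity, read by MTT assay, with a stated time of 72 h; on this read-out higher numbers stand for weaker inhibition and lower numbers for stronger inhibition. Compound 1 gives 7940 nM in this assay, the highest of the two numbers shown; the only neighbour is compound 2, and the step of a 1.8-fold lower number from compound 1 to compound 2 (0.26 log units; within the scatter) does not rise above the scatter, so the two compounds cannot be set in order.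

Compound 3, `COc1cc(-n2cnc3ccc(-c4ccc(Cl)cc4Cl)cc32)cc(OC)c1OC`, has not yet been measured in this assay. It differs from compound 1 in one place: 2,4-dichlorophenyl in place of 2,5-difluorophenyl on an aromatic carbon.

For the measured compounds named here, the one measured step that bears on this change is the swap of the aryl group at the same position, the 2-methoxyphenyl for the 2,5-difluorophenyl, which gave a 1.8-fold lower number from compound 1 to compound 2 (0.26 log units; within the scatter) and stayed within the scatter. Going by the values given here, since the only aryl exchange at this position left the number essentially unchanged, and nothing else in the data speaks to a dichlorophenyl, the step expected for compound 3 in this assay is a 1.3-fold lower number from compound 1 to compound 3 (0.12 log units; within the scatter), a change that is not expected to exceed the scatter. Compound 3 is therefore estimated at 6000 nM, within a range from 2500 nM to 15000 nM.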

Compound 3, half-maximal inhibitory concentration: > 10000 nM
Compound 3: a limit, no number (the forecaster's own chance of this, stated with the estimate: 5%); middle value at least 1.6-fold (0.22 log units) away from the limit.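

In this assay, compound 3 carries a limit of the assay and not a number: the limit of > 10000 nM in this assay, at which 1 of the 3 values shown sits. Even so, replacing 2-methoxyphenyl with 2,4-dichlorophenyl on this aromatic carbon gives an at least 2.3-fold higher number from compound 2 to compound 3 (0.36 log units; beyond the scatter), so the choice of aryl group at this position can move the number beyond the scatter, which the earlier pair did not show. Replacing 2,5-difluorophenyl with 2,4-dichlorophenyl gives only an at least 1.2-fold higher number from compound 1 to compound 3 (0.10 log units; that floor lies within the scatter), so this pair cannot be set in order, and the exchange may be small or large.

For the compounds shown here, the true size of both steps stays unknown, and with only three aryl groups at this position, no trend can be drawn among them and no reason for the shift can be given. As far as these compounds go, it also remains open how a plain phenyl group would read in this assay, and whether an aryl group carrying an amine or a carboxylic acid would bring the number lower than the 2-methoxyphenyl group does.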